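The source may hold more compounds than are shown below. What is called first, only, known or untested is meant among the compounds shown, and "the series" means these compounds.

Measured so far:
- compound 1, `Cc1ccc(Nc2nc(C(F)(F)F)ccc2CNC(=O)C(C)c2ccc(NS(C)(=O)=O)c(F)c2)cc1C`: 39.3 nM
- compound 2, `C[C@H](C(=O)NCc1ccc(C(F)(F)F)nc1N1CC[C@@H](OCc2ccccc2)C1)c1ccc(NS(C)(=O)=O)c(F)c1`: 1.4 nM
- compound 3, `Cc1ccc(CC2CCN(c3nc(C(F)(F)F)ccc3CNC(=O)C(C)c3ccc(NS(C)(=O)=O)c(F)c3)CC2)cc1`: 0.2 nM

All three compounds were tested in a functional assay on CHO-K1 cells for antagonist activity at transient receptor potential cation channel subfamily V member 1 (Homo sapiens), read by FLIPR; a lower number here means a stronger inhibitor, a higher number a weaker inhibitor. Compound 1 has the highest number of the three, so it is the weakest inhibitor here. Compound 2, with 1.4 nM, sits closest to it, and compound 3, with 0.2 nM, is furthest away; both gaps are wider than the usual scatter. The two stronger compounds carry a saturated ring amine at the place where compound 1 carries an aromatic amine bearing a hydrogen.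

Compound 4, `CC(C(=O)NCc1ccc(C(F)(F)F)nc1N1CCCCCC1)c1ccc(NS(C)(=O)=O)c(F)c1`, has not been measured. It differs from compound 1 in one place: azepan-1-yl in place of (3,4-dimethylphenyl)amino on an aromatic carbon. The incoming group is a seven-membered non-aromatic ring with one nitrogen and no hydrogen-bond donor, which brings compound 4 closer in kind to compounds 2 and 3 than to compound 1. On that basis the step from compound 1 to compound 4 is expected to go down, toward stronger inhibition, by more than the scatter, though the plain azepan-1-yl carries no further substituent like those in compounds 2 and 3, so a smaller drop than to those two seems likely. The expected step is a 7.9-fold lower number from compound 1 to compound 4 (0.90 log units; beyond the scatter). Compound 4 is therefore estimated at 5 nM in this assay, within a range from 1 nM to 25 nM.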

Compound 4, inhibition constant: 0.8 nM
The estimate for compound 4 lay 6.3-fold (0.80 log units) above the measured number; the measured number lies below the stated range.
By their numbers in this assay, from the lowest: compound 3; then compounds 4 and 2 (each within the scatter of the next); then compound 1.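

In this assay, going by these compounds alone, azepan-1-yl in place of (3,4-dimethylphenyl)amino on an aromatic carbon gives a 49-fold lower number from compound 1 to compound 4 (1.69 log units; beyond the scatter), the only step here that can be read across a single change. Compounds 2 and 3 also carry a non-aromatic ring amine at this position, but their rings bear further substituents, whereas compound 4 shows that a ring with no added group can already give a large step away from compound 1. The swap removes the aromatic ring and the hydrogen-bond donor together and also alters the size of the group, and no measurement here bears on why the number falls.

The compounds shown therefore leave open whether the aromatic ring, the amine hydrogen, or both account for the step: cyclohexylamino would keep the hydrogen without the aromatic ring, while N-methyl-(3,4-dimethylphenyl)amino would keep the aromatic ring without the hydrogen. They also leave open how much the seven-membered ring itself matters, which plain piperidin-1-yl or morpholin-4-yl at the same position would test.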